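The source may report more compounds than this note shows. Statements on the series, on what has been measured and on what is new or still open speak of the compounds shown alone.

Compound 1 `O=C(O)c1csc([C@H]2CC[C@@H]3[C@@H](/C=C/[C@@H](O)COc4ccccc4)[C@H](O)C[C@@H]3O2)n1` gives the lowest number of the three measured compounds in a functional assay on CHO cells for agonist activity at prostaglandin E2 receptor EP1 subtype (Homo sapiens), read by fluorescence and calcium flux (on this read-out lower numbers stand for an effect already at smaller amounts and higher numbers for an effect only at larger amounts of compound), at 1.4 nM; compound 3 `O=C(O)c1csc([C@H]2CC[C@@H]3[C@@H](CCOc4ccccc4)[C@H](O)C[C@@H]3O2)n1` gives 97 nM and compound 2 `O=C(O)c1csc([C@H]2CC[C@@H]3[C@@H](CCCOc4ccccc4)[C@H](O)C[C@@H]3O2)n1` gives 4200 nM. Compound 4 `O=C(O)c1csc([C@H]2CC[C@@H]3[C@@H](/C=C/CCCOc4ccccc4)[C@H](O)C[C@@H]3O2)n1` is not yet measured. It differs from compound 1 by 3-phenoxypropyl in place of 1-hydroxy-2-phenoxyethyl on a double-bonded chain carbon bound to a double-bonded chain carbon. Among the measured compounds shown here, the one measured step that bears on this is a 43-fold lower number from compound 2 to compound 3 (1.64 log units; beyond the scatter), where a shorter link between the core and the phenoxy group went with a far lower number. Compound 4 carries a longer link than compound 1 and loses the hydroxyl, so in this assay a large rise in number is expected, a 1400-fold higher number from compound 1 to compound 4 (3.15 log units; beyond the scatter). Compound 4 is therefore estimated at 2000 nM, within a range from 200 nM to 20000 nM.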

Compound 4, half-maximal effective concentration: 970 nM
For compound 4 the middle estimate is 2.1-fold (0.31 log units) above the measured one; the range from low to high includes it.
By their numbers in this assay, from the lowest: compound 1; then compound 3; then compound 4; then compound 2.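

In this assay, 3-phenoxypropyl in place of 1-hydroxy-2-phenoxyethyl on a double-bonded chain carbon bound to a double-bonded chain carbon brings a 690-fold higher number from compound 1 to compound 4 (2.84 log units; beyond the scatter) even though both groups hold the same number of heavy atoms and the same aromatic ring. The change removes the hydrogen-bond donor and the defined stereocentre and also moves the ether oxygen, so this single step cannot separate these changes. Nothing measured here explains the size of the step. The compounds shown leave open how a methoxy group or an amine in place of the hydroxyl of compound 1 would read.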